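The source may report more compounds than this note shows. Statements on the series, on what has been measured and on what is new or still open speak of the compounds shown alone.

Compounds measured in an assay for inhibition of Alpha amylase (Homo sapiens), with a stated time of 30 min; on this read-out lower numbers stand for stronger inhibition and higher numbers for weaker inhibition:

Compound 1, `CCOC(=O)c1c(-c2ccccc2)nn(-c2ccccc2)c1Cn1c(S)nc2ccccc21`, gives 40 ug/mL.
Compound 2, `CCOC(=O)c1c(-c2ccccc2)nn(-c2ccccc2)c1Cn1c(S)nc2ccc(OC(F)F)cc21`, gives 10 ug/mL.
Compound 3, `CCOC(=O)c1c(-c2ccccc2)nn(-c2ccccc2)c1COCc1c(-c2ccc(F)cc2)nc(N(C)S(C)(=O)=O)nc1C(C)C`, gives 15 ug/mL.

Among these three, compound 1 stands at the highest number, so it is the weakest inhibitor of the set; compound 2 and compound 3 both lie lower by more than the usual scatter. For the measured compounds named here, the only single-change step available is a 4.0-fold lower number from compound 1 to compound 2 (0.60 log units; beyond the scatter), a modest gain that comes from adding a difluoromethoxy group to the six-membered ring of the benzimidazole part while the rest of compound 1 is kept.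

Compound 4, `CCOC(=O)c1c(-c2ccccc2)nn(-c2ccccc2)c1Cn1cnc2cc(C)ccc21`, changes the same part of compound 1 in a different way: a group of 10 heavy atoms (8 carbon, 2 nitrogen; one five-membered aromatic ring with 2 hetero atoms, one six-membered aromatic ring of carbon only) in place of a group of 10 heavy atoms (7 carbon, 2 nitrogen, 1 sulfur; one five-membered aromatic ring with 2 hetero atoms, one six-membered aromatic ring of carbon only), on a saturated chain carbon bound to an aromatic carbon. The sulfur of compound 1 does not return, and a methyl group appears on the six-membered ring instead. Going by the values given here, no measured step tells what removing the sulfur does, and the step from compound 1 to compound 2 touches only the six-membered ring, so it offers weak guidance at best. The expectation is therefore cautious: compound 4 is estimated at 60 ug/mL, within 20 ug/mL to 180 ug/mL, which means an expected step of a 1.5-fold higher number from compound 1 to compound 4 (0.18 log units; within the scatter), possibly no change beyond the scatter.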

Compound 4, half-maximal inhibitory concentration: 45 ug/mL
Compound 4: middle estimate off by 1.3-fold (0.12 log units), on the high side, within the range that was stated.
By their numbers in this assay, from the lowest: compounds 2 and 3 (each within the scatter of the next); then compounds 1 and 4 (each within the scatter of the next).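

In this assay, replacing the sulfur-bearing group of compound 1 with 5-methyl-1H-benzimidazol-1-yl, on a saturated chain carbon bound to an aromatic carbon, gives a 1.1-fold higher number from compound 1 to compound 4 (0.05 log units; within the scatter). This position therefore accepts a group with 0 hydrogen-bond donors and no sulfur in place of one with 1 hydrogen-bond donor and a sulfur, without a change beyond the usual scatter, something the earlier step on the six-membered ring could not show. No measurement available here explains why this exchange leaves the number within the scatter.

The loss of the sulfur and the gain of the methyl group arrive together, so their separate effects cannot be read, and they may or may not cancel. Also open, on these data alone, is whether an amine in place of the sulfur would shift the number, and whether a difluoromethoxy group would bring the same gain in a compound without the sulfur.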